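The compounds below may be only part of what the source reports. "The series", "measured", "known", "first", "only" and "open" are said of these compounds alone.

Three compounds from one series were tested in an assay on isolated protein for inhibition of DNA topoisomerase 1 (Homo sapiens), with a stated time of 30 min, tested at 100 uM; on this read-out lower numbers stand for a weaker effect and higher numbers for a stronger effect at the one concentration tested. Compound 1 `Oc1ccc(-c2cc(-c3ccccn3)nc(-c3ccccc3Cl)c2)cc1` gives 5.2% in this assay. Compound 2 `Oc1ccc(-c2cc(-c3ccccc3)nc(-c3ccccc3Cl)c2)cc1` keeps the same arrangement except for one change, (phenyl in place of pyridin-2-yl on an aromatic carbon), and in this assay compound 2 gives 13.6%; the step of a number 8.4 percentage points higher from compound 1 to compound 2 (within the scatter) is one that the method cannot tell from no change at all. Compound 3 `Oc1cccc(-c2cc(-c3ccc(Cl)cc3)nc(-c3ccccn3)c2)c1` is built from the same atoms as compound 1, joined differently; how the two cores differ is not broken down here. In this assay compound 3 gives 30%, the highest of the three numbers, and its distance from compound 2 and from compound 1 lies beyond the usual scatter.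

Compound 4 `Oc1cccc(-c2cc(-c3ccccc3)nc(-c3ccc(Cl)cc3)c2)c1` has not yet been measured. It differs from compound 3 by phenyl in place of pyridin-2-yl on an aromatic carbon. This is the same kind of change as that from compound 1 to compound 2, but not the same: there the place was meta to a 2-chlorophenyl group and meta to a 4-hydroxyphenyl group, here it is meta to a 3-hydroxyphenyl group and meta to a 4-chlorophenyl group. Compound 4 is therefore expected to move from compound 3 by about a number 6 percentage points higher from compound 3 to compound 4 (within the scatter), a step of the same small size, because the same kind of change earlier gave a number 8.4 percentage points higher from compound 1 to compound 2 (within the scatter). On that basis compound 4 is estimated to reach 36% in this assay, most plausibly between 16% and 56%.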

Compound 4, a percentage reported as inhibition, at one concentration (the size of the read-out at that concentration, not a potency): 7.1%
Compound 4: middle estimate off by 28.9 percentage points, on the high side; measured number outside the range, below it.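

In this assay the change from pyridin-2-yl to phenyl gives a number 22.9 percentage points lower from compound 3 to compound 4 (beyond the scatter) on the core of compound 3, whereas on the core of compound 1 the same change gave a number 8.4 percentage points higher from compound 1 to compound 2 (within the scatter) and could not be told from no change, so in this series the step does not carry over from one core to the other as a fixed amount: the same change on two cores in this assay, a number 8.4 percentage points higher (within the scatter) from compound 1 to compound 2 and a number 22.9 percentage points lower (beyond the scatter) from compound 3 to compound 4, 31.3 percentage points apart, beyond the scatter of two such steps. The outcome therefore has to be read separately on each core, and a step seen on one of them gives no safe guide to the size or direction of the step on the other. Within the data shown here, this rests on only two pairs, however, and the two cores differ in more than one respect, one carrying a 2-chlorophenyl and a 4-hydroxyphenyl group and the other a 4-chlorophenyl and a 3-hydroxyphenyl group, so the data do not show which of these differences accounts for the gap, nor why it arises.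

As far as these compounds go, it remains open how either core would respond if a group other than phenyl, such as a pyridin-3-yl ring or a ring bearing an amine, took the place of pyridin-2-yl. From the compounds shown here alone, it is also open whether a methoxy group or a carboxylic acid in place of the hydroxy group would change how far the step carries from one core to the other.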